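The compounds below may be only part of what the source reports. "The series", "measured", "known", "first", "only" and "open" are said of these compounds alone.

Compound 1, `O=c1nc(N2CCN(NCCC3CCCCC3)CC2)sc2c([N+](=O)[O-])cc(C(F)(F)F)cc12`: in an ADME assay on Vero cells (Chlorocebus sabaeus) for cytotoxicity, read by MTT assay, with a stated time of 72 h (on this read-out higher numbers stand for lower toxicity in this test and lower numbers for higher toxicity in this test), compound 1 gives > 64 ug/mL, which is a limit of the assay.
Compound 2, `CN(CC1CCCCC1)N1CCN(c2nc(=O)c3cc(C(F)(F)F)cc([N+](=O)[O-])c3s2)CC1`: in this assay compound 2 gives > 64 ug/mL, also a limit.
Compound 3, `O=c1nc(N2CCN(NCc3ccc(OC(F)(F)F)cc3)CC2)sc2c([N+](=O)[O-])cc(C(F)(F)F)cc12`: in this assay compound 3 gives > 64 ug/mL, again a limit.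

Within the data shown here, compound 3 therefore stands where every value so far stands: at the limit of > 64 ug/mL in this assay, at which 3 of the 3 values shown sit. No compound in this set has shown a measurable toxicity in this assay.

Compound 4, `O=c1nc(N2CCN(NCc3ccc(F)cc3)CC2)sc2c([N+](=O)[O-])cc(C(F)(F)F)cc12`, differs from compound 3 in one place: fluoro in place of trifluoromethoxy on an aromatic carbon. The two measured steps, a step that the two limits leave unreadable from compound 1 to compound 2 and a step that the two limits leave unreadable from compound 1 to compound 3, change the side chain on the shared core, but both run from one limit to another, so neither gives a readable size. Nothing here points to a step in either direction for compound 4 in this assay. The expectation is that compound 4 again reaches the limit, with an estimated value of 80 ug/mL, in a range from 40 ug/mL to 200 ug/mL, so that the expected step that the limit leaves unreadable from compound 3 to compound 4 is none beyond the scatter.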

Compound 4, half-maximal cytotoxic concentration: > 64 ug/mL
Compound 4 was reported as a limit (the forecaster's own chance of this, stated with the estimate: 85%); the middle value lies beyond the limit too.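

In this assay compound 4 gives only a limit, as do compound 1, compound 2 and compound 3, so no step to compound 4 can be read: the limit of > 64 ug/mL in this assay, at which 4 of the 4 values shown sit.

Where the true values of these four compounds lie, and whether fluoro in place of trifluoromethoxy changes toxicity at all, stays open.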